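The source may hold more compounds than are shown below. What is called first, only, known or untested is meant among the compounds shown, and "the series" means these compounds.

Of the compounds shown here, three sharing one core have so far been read in an in vitro ADME assay on microsomes from liver (Simiiformes); on this read-out lower numbers stand for a shorter-lived compound and higher numbers for a longer-lived compound. Compound 1 `Cc1cc(CCCOc2c(C)cc(-c3noc(CC(F)(F)F)n3)cc2C)on1` gives 0.533 h, compound 2 `Cc1cc(CCCOc2c(C)cc(-c3noc(CF)n3)cc2C)on1` gives 0.233 h, and compound 3 `Cc1cc(CCCOc2c(C)cc(-c3noc(C(N)=O)n3)cc2C)on1` gives 2.3 h, the highest of the three numbers. Compound 4 `Cc1cc(CCCOc2c(C)cc(-c3noc(C4CC4)n3)cc2C)on1` is still unmeasured. It places cyclopropyl in place of carbamoyl on an aromatic carbon, the change counted here: cyclopropyl in place of carbamoyl on an aromatic carbon.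

The nearest evidence comes from the two steps that end at carbamoyl: a 4.3-fold higher number from compound 1 to compound 3 (0.64 log units; beyond the scatter), and a 9.9-fold higher number from compound 2 to compound 3 (0.99 log units; beyond the scatter). Both rise on reaching carbamoyl and both lie beyond the scatter. Leaving carbamoyl for another group has so far meant a lower number, but only two groups show this, and neither is cyclopropyl. The step of a 2.3-fold lower number from compound 1 to compound 2 (0.36 log units; beyond the scatter) shows how far the two non-carbamoyl compounds themselves lie apart.

A fall beyond the scatter is therefore expected, estimated as a 4.6-fold lower number from compound 3 to compound 4 (0.66 log units; beyond the scatter). For compound 4 the estimated half-life is 0.5 h, with an expected range from 0.17 h to 1.4 h.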

Compound 4, half-life: 2.23 h
For compound 4 the middle estimate is 4.5-fold (0.65 log units) below the measured one; measured number above the stated range.
By their numbers in this assay, from the lowest: compound 2; then compound 1; then compounds 4 and 3 (each within the scatter of the next).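

Cyclopropyl in place of carbamoyl gives a 1.0-fold lower number from compound 3 to compound 4 (0.01 log units; within the scatter) in this assay, so at this position carbamoyl is not the only group that reaches the higher numbers, and a hydrogen-bond donor and acceptor on the group are not needed for them. Compared with the two fluorinated groups, cyclopropyl gives a 9.6-fold higher number from compound 2 to compound 4 (0.98 log units; beyond the scatter) and a 4.2-fold higher number from compound 1 to compound 4 (0.62 log units; beyond the scatter), which means the low numbers so far belong to fluoromethyl and 2,2,2-trifluoroethyl rather than to every group other than carbamoyl. Nothing measured here explains why these groups differ.

Still open, on these data alone, is where other groups at this position would fall, such as an amine, a carboxylic acid or a longer carbon chain. Plain methyl and ethyl, which carry no fluorine, would also show whether the low numbers go with the fluorine atoms or with the chains that carry them.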